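The source may report more compounds than this note shows. Statements on the series, on what has been measured and on what is new or still open speak of the compounds shown alone.

Of the compounds shown here, three have so far been measured in a functional assay on HeLa cells (Homo sapiens) for antiproliferative activity, read by MTT assay, with a stated time of 48 h; a higher number here means a weaker inhibitor, a lower number a stronger inhibitor. Compound 1 (`C=C(c1ccc(OC)cc1NC(=O)CO)c1ccc(OC)c2c1OC(C)(C)C=C2`) gives 40 nM, compound 3 (`C=C(c1cc(OC)c(OC)c(OC)c1)c1ccc(OC)c(O)c1NC(C)=O`) gives 90 nM and compound 2 (`C=C(c1ccc2c(c1)C=CC(C)(C)O2)c1ccc(OC)cc1NC(=O)CNCC`) gives 1580 nM. Compound 3 therefore holds the middle place, and its gaps to both neighbours lie beyond the scatter, the gap to compound 1 being much the smaller. Compound 4 (`C=C(c1cc(OC)c(OC)c(OC)c1)c1ccc(OC)c(O)c1NC(=O)CN(C)C`) keeps the rest of compound 3 and changes one spot: dimethylamino in place of hydrogen on a saturated chain carbon bound to a carbonyl carbon. Within the data shown here, no measured pair isolates this change. The nearest guide is compound 2, which carries an ethylamino group on such a carbon and reads 1580 nM, but its core differs too. Compound 1, with a hydroxy group there, reads 40 nM, so substitution at this carbon need not be costly. A modest loss in this assay is therefore expected, an estimated 2.2-fold higher number from compound 3 to compound 4 (0.35 log units; beyond the scatter). For compound 4 the estimated value is 200 nM, with an expected range of 60 nM to 700 nM.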

Compound 4, half-maximal inhibitory concentration: 120 nM
The estimate for compound 4 lay 1.7-fold (0.22 log units) above the measured number; measured number inside the range.
By their numbers in this assay, from the lowest: compound 1; then compounds 3 and 4 (each within the scatter of the next); then compound 2.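

In this assay, among these compounds, the change reads as a 1.3-fold higher number from compound 3 to compound 4 (0.12 log units; within the scatter) and gives the first direct look at this position. On the saturated chain carbon bound to a carbonyl carbon, dimethylamino, with its 3 heavy atoms, takes the place of hydrogen on this core with no change that can be told from the scatter. Nothing available explains this result.

The compounds shown leave open whether a carboxylic acid, a morpholine ring or a longer chain ending in an amine would be taken up equally well at this carbon. They also leave open whether dimethylamino would read the same way on the core of compound 1 or on that of compound 2, since this single pair speaks only for the core of compound 3.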